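A few compounds are considered here, and "the series" means these few. Any claim that something is new, unique, unknown or untested is made for them only; others in the source may bear on it.

Measured in an ADME assay on the whole organism (strain Sprague-Dawley) for pharmacokinetics, with Rattus norvegicus as the target, at a dose of 30 mg/kg by the oral route; a higher number here means more compound in the circulation at the dose given, a lower number less compound in the circulation:
- compound 1 `CC(=O)Nc1nc(C)c(-c2nc(CC(F)(F)F)no2)s1` gives 1130 nM
- compound 2 `CC(=O)Nc1nc(C)c(-c2nc(CC(C)(C)CO)no2)s1` gives 122 nM

Compound 2, at 122 nM, holds the lower of the two numbers in this assay, and the gap to compound 1 lies beyond the scatter. The next structure is compound 3 `CC(=O)Nc1nc(C)c(-c2nc(CC(C)(C)C(C)O)no2)s1`, which differs from compound 2 by methyl in place of hydrogen on a saturated chain carbon bound to an oxygen on a saturated carbon and a saturated chain carbon. This turns hydroxymethyl into 1-hydroxyethyl, so the side chain becomes 3-hydroxy-2,2-dimethylbutyl.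

Among the measured compounds shown here, only one measured step bears on this, and only loosely: a 9.3-fold lower number from compound 1 to compound 2 (0.97 log units; beyond the scatter). That step swaps trifluoromethyl for 1-(hydroxymethyl)-1-methylethyl in the same side chain, a far larger replacement than the one methyl now added. For the measured compounds named here, no measured pair shows the effect of a methyl at this carbon, so the data give no direction for the change. The step seen between compound 1 and compound 2 therefore sets only a loose outer bound, and the range is kept wide on both sides.

The expected step is a 1.1-fold higher number from compound 2 to compound 3 (0.03 log units; within the scatter), which would stay within the scatter. For compound 3 the estimated value is 130 nM, with an expected range of 40 nM to 420 nM.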

Compound 3, maximal plasma concentration: 24000 nM
The estimate for compound 3 lay 180-fold (2.27 log units) below the measured number, outside the stated range (above it).
By their numbers in this assay, from the lowest: compound 2; then compound 1; then compound 3.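

In this assay, one methyl on the saturated chain carbon bound to an oxygen gives the largest step in the series (a 200-fold higher number from compound 2 to compound 3 (2.29 log units; beyond the scatter)), so this carbon, untouched by the earlier pair, is a highly sensitive place in the side chain. The change from hydroxymethyl to 1-hydroxyethyl also carries the side chain past trifluoromethyl (a 21-fold higher number from compound 1 to compound 3 (1.33 log units; beyond the scatter)), so the earlier drop (a 9.3-fold lower number from compound 1 to compound 2 (0.97 log units; beyond the scatter)) does not hold for hydroxyl-bearing side chains in general: compound 2 lies under compound 1, while compound 3 lies over it. Nothing measured in the series accounts for the size of this jump.

Still open, going by these compounds, is whether the rise depends on the hydroxyl group or on the added carbon alone, a question that a methoxy group or a ketone at this carbon would help to separate. Also open, on these data alone, is how an ethyl group or a longer chain in place of the new methyl would shift the number, since a single methyl is the only addition seen at this carbon.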